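The source may hold more compounds than are shown below. What is called first, only, known or untested is meant among the compounds shown, and "the series" means these compounds.

Working notes on the series. For the measured compounds named here, compound 1 `C=CCn1c(=O)/c(=C\c2cccc(C)c2)[nH]c(=O)/c1=C\c1ccccc1OC` is tested in a functional assay on MOLT-4 cells (Homo sapiens) for cytotoxicity, read by CCK-8 assay, with a stated time of 72 h (a lower number here means a stronger inhibitor, a higher number a weaker inhibitor), and gives 16000 nM; it is the only member with a number so far. Going by the values given here, compound 2 `C=CCn1c(=O)/c(=C\c2cccc(Br)c2)[nH]c(=O)/c1=C\c1cccc(Br)c1` is reported in this assay as "not active" (no number reported), without a figure, so no step between measured compounds can be drawn. Compound 3 `C=CCn1c(=O)/c(=C\c2ccccc2F)[nH]c(=O)/c1=C\c1ccccc1OC` remains to be measured in this assay. It differs from compound 1 by 2-fluorophenyl in place of 3-methylphenyl on a double-bonded chain carbon bound to an aromatic carbon. Among the compounds with values here, with no comparable step available, the expected change a 1.3-fold higher number from compound 1 to compound 3 (0.10 log units; within the scatter) is small, within scatter or slightly toward weaker inhibition. Compound 3 is therefore estimated at 20000 nM, with a likely range from 7000 nM to 60000 nM.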

Compound 3, half-maximal inhibitory concentration: 20000 nM
For compound 3 middle estimate and measured number coincide at the digits printed; the range from low to high includes it.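

In this assay, for the compounds shown here, 2-fluorophenyl in place of 3-methylphenyl on a double-bonded chain carbon bound to an aromatic carbon gives a 1.3-fold higher number from compound 1 to compound 3 (0.10 log units; within the scatter) as the first readable step. At this position, the two groups are not distinguished by this read-out. No supporting measurement accounts for this result.

As far as these compounds go, it remains open whether an amine or a carboxylic acid at this position would give a number clearly apart from those of compound 1 and compound 3. From the compounds shown here alone, the effect of changing the allyl group on the shared core also remains open.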